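The compounds below may be only part of what the source reports. "The series", "measured", "known", "first", "only" and "open" are said of these compounds alone.

Measured compounds:
compound 1, `Cc1nc(C)c(-c2nn(-c3ccc(F)cc3)cc2/C=C/C(=O)c2cc(Cl)ccc2O)s1`: > 250 ug/mL
compound 2, `Cc1nc(C)c(-c2nn(-c3ccc(F)cc3)cc2/C=C/C(=O)c2cc(Cl)cc(Cl)c2O)s1`: > 250 ug/mL
compound 3, `Cc1nc(C)c(-c2nn(-c3ccc(F)cc3)cc2/C=C/C(=O)c2cc(Cl)c(C)cc2O)s1`: 34.9 ug/mL

In an ADME assay on HeLa cells (Homo sapiens) for inhibition, read by MTT assay (on this read-out higher numbers stand for weaker inhibition of growth and lower numbers for stronger inhibition of growth), compound 1 returns only a limit, > 250 ug/mL. Compound 2 likewise returns only a limit, > 250 ug/mL. Among the compounds with values here, compound 3 is the single compound with an actual number, 34.9 ug/mL, and so sits alone among the three below (the limit of > 250 ug/mL in this assay, at which 2 of the 3 values shown sit).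

Compound 4, `Cc1nc(C)c(-c2nn(-c3ccc(F)cc3)cc2/C=C/C(=O)c2c(O)cc(C)c(Cl)c2C)s1`, differs from compound 3 by methyl in place of hydrogen on an aromatic carbon.

Within the data shown here, the only measured step of the same kind, methyl in place of hydrogen on an aromatic carbon, is an at least 7.1-fold lower number from compound 1 to compound 3 (0.85 log units; beyond the scatter), and it is echoed by an at least 7.1-fold lower number from compound 2 to compound 3 (0.85 log units; beyond the scatter); both start from a limit, so they give a lower bound only. The step that the two limits leave unreadable from compound 1 to compound 2 adds nothing readable. Among the measured compounds shown here, no measured pair shows a second methyl entering the same ring, so a further step of that size is not assumed; a small lowering or none beyond the scatter is expected in this assay.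

Compound 4 is therefore estimated at 25 ug/mL, within 8 ug/mL to 90 ug/mL, which means an expected step of a 1.4-fold lower number from compound 3 to compound 4 (0.14 log units; within the scatter).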

Compound 4, concentration for 50% growth inhibition: 59.3 ug/mL
Estimate against measurement, compound 4: 2.4-fold (0.38 log units) below; low and high end bracket the measured number.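

In this assay, methyl in place of hydrogen ortho to a chloro group and ortho to a large group gives a 1.7-fold higher number from compound 3 to compound 4 (0.23 log units; within the scatter) and so stays within the scatter, whereas the methyl step at the other ring position gave an at least 7.1-fold lower number from compound 1 to compound 3 (0.85 log units; beyond the scatter) and lay beyond it. The second methyl therefore leaves compound 4 clear of the limit compounds, with an at least 4.2-fold lower number from compound 2 to compound 4 (0.62 log units; beyond the scatter) and with an at least 4.2-fold lower number from compound 1 to compound 4 (0.62 log units; beyond the scatter) as well. Those last two steps are lower bounds only, as each starts from a limit: the limit of > 250 ug/mL in this assay, at which 2 of the 4 values shown sit.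

On these data alone, whether this position also accepts an ethyl, a methoxy or an amine stays open. Also open, as far as these compounds go, is what this methyl does on compound 1, whose ring carries no other methyl.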